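The compounds below may be only part of what the source reports. "The series", "measured", "known", "first", "only" and "open" are said of these compounds alone.

Measured in a functional assay on ACHN cells (Homo sapiens) for antiproliferative activity, read by sulforhodamine B assay, with a stated time of 48 h; a higher number here means a weaker inhibitor of growth, a lower number a stronger inhibitor of growth:
- compound 1 `O=C(NCCCNc1cc(-c2cn(-c3ccccc3)nc2-c2cccc(O)c2)ccn1)Nc1ccc(F)cc1`: 14200 nM
- compound 2 `O=C(NCCCNc1cc(-c2cn(-c3ccccc3)nc2-c2cccc(O)c2)ccn1)Nc1cccc(C(F)(F)F)c1`: 15500 nM

Going by the values given here, compound 1 stands level with compound 2, the only other measured compound, and the step between them is a 1.1-fold higher number from compound 1 to compound 2 (0.04 log units; within the scatter). Neither compound stands apart in this assay.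

Compound 3 `COc1cccc(-c2nn(-c3ccccc3)cc2-c2ccnc(NCCCNC(=O)Nc3ccc(F)cc3)c2)c1` keeps the core of compound 1 and changes one place: methyl in place of hydrogen on an oxygen on an aromatic ring, that is, 3-hydroxyphenyl to 3-methoxyphenyl. Among the compounds with values here, no measured step touches this group. Within the data shown here, the one available step, at an amide-type nitrogen, bears only indirectly and shows a change elsewhere passing within the scatter. No step beyond the scatter is therefore expected, though with little certainty. The estimated step is a 1.1-fold higher number from compound 1 to compound 3 (0.02 log units; within the scatter). For compound 3 the expected value is 15000 nM, with an estimated range of 6000 nM to 38000 nM.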

Compound 3, concentration for total growth inhibition: > 37000 nM
Compound 3 was reported as a limit (the forecaster's own chance of this, stated with the estimate: 10%); at least 2.4-fold (0.39 log units) between middle value and limit.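

In this assay, the hydroxy of the 3-hydroxyphenyl group proves more sensitive than the earlier change at the amide-type nitrogen, which gave only a 1.1-fold higher number from compound 1 to compound 2 (0.04 log units; within the scatter). Going from 3-hydroxyphenyl to 3-methoxyphenyl gives an at least 2.6-fold higher number from compound 1 to compound 3 (0.41 log units; beyond the scatter), so methyl in place of hydrogen on this oxygen is not tolerated as the aryl swap was, and the free hydroxy matters for growth inhibition in this series. The figure for compound 3 is a limit and not a number: the limit of > 37000 nM in this assay, at which 1 of the 3 values shown sits.

Going by these compounds, the full size of this step remains open, and a single methoxy compound cannot separate loss of the hydroxy hydrogen from the added methyl. The compounds shown do not tell how a 3-aminophenyl group, or a longer chain on the oxygen such as ethoxy, would read here.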